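A few compounds are considered here, and "the series" means these few. Any claim that something is new, unique, unknown or untested is made for them only; others in the source may bear on it.

In a functional assay on MCF7 cells (Homo sapiens) for inhibition, read by resazurin assay, with a stated time of 72 h (on this read-out lower numbers stand for stronger inhibition and higher numbers for weaker inhibition), two compounds have been measured:

compound 1 `C=CC1C(=O)N(c2cc(OC)c(OC)c(OC)c2)C1c1ccc(SC)cc1`: 51 nM
compound 2 `COc1cc(N2C(=O)C(O)C2c2ccc(SC)cc2)cc(OC)c1OC`: 5 nM

Of these two, compound 1 has the higher number, and so the weaker inhibition, at 51 nM. The next compound to be tested is compound 3 `C=CC1C(=O)N(c2cc(OC)c(OC)c(OC)c2)C1c1ccc(OCC)cc1`, which keeps the vinyl group of compound 1. The change is ethoxy in place of methylsulfanyl on an aromatic carbon, with ethoxy in place of methylsulfanyl on an aromatic carbon.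

Among the measured compounds shown here, only one measured step is available, a 10-fold lower number from compound 1 to compound 2 (1.01 log units; beyond the scatter). For the measured compounds named here, this step is large and beyond the scatter, but it is the swap of hydroxy for vinyl on a saturated ring carbon, a different place from the one altered in compound 3. It therefore says little about the new change. Going by the values given here, no measured pair shows what happens when methylsulfanyl is replaced, so no large step is expected in this assay, and any shift is expected to stay within the scatter, perhaps with a slightly higher number. The estimate corresponds to an expected 1.2-fold higher number from compound 1 to compound 3 (0.07 log units; within the scatter). The expected value for compound 3 is 60 nM, with an estimated range from 20 nM to 200 nM.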

Compound 3, half-maximal inhibitory concentration: 14 nM
Beside the measured number, compound 3's estimate is 4.3-fold (0.63 log units) above it; measured number below the stated range.
By their numbers in this assay, from the lowest: compound 2; then compound 3; then compound 1.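

The aromatic carbon para to a large group, which the earlier pair left untouched, turns out to respond in this assay: with the vinyl group kept, ethoxy in place of methylsulfanyl gives a 3.6-fold lower number from compound 1 to compound 3 (0.56 log units; beyond the scatter) as a modest step beyond the scatter. Methylsulfanyl is therefore not required at this position for a low number on the core of compound 1, and the vinyl group and this aromatic position have now each been shown to move the read-out when changed on their own. No evidence is at hand that bears on why this change lowers the number.

The compounds shown leave open whether ethoxy in place of methylsulfanyl would also lower the number when hydroxy rather than vinyl sits on the saturated ring carbon, as in compound 2, since the two changes have so far been seen only apart. Going by these compounds, it also remains open how an amine, a carboxylic acid or a longer chain such as butoxy would read at this aromatic position.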